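Acylguanidines with a varied aromatic substituent

This account rests on a few compounds, and the source may have more. Where it says the series, first, only, none or still open, it means among the compounds named here.

Measured compounds:
Compound 1 `Cc1cc(SC(C)C)c(S(C)(=O)=O)cc1C(=O)N=C(N)N` gives 12 nM in a functional assay for inhibition of sodium/hydrogen exchanger (Oryctolagus cuniculus); on this read-out lower numbers stand for stronger inhibition and higher numbers for weaker inhibition.
Compound 2 `Cc1cc(Oc2ccccc2)c(S(C)(=O)=O)cc1C(=O)N=C(N)N` gives 10 nM in this assay.

Among the two numbers shown, compound 2 gives the lowest, with compound 1 nearest; the difference a 1.2-fold lower number from compound 1 to compound 2 (0.08 log units; within the scatter) is within the scatter, so no order between them can be claimed. Compound 3 `Cc1cc(C#N)c(S(C)(=O)=O)cc1C(=O)N=C(N)N` has not yet been measured. It differs from compound 2 as follows: cyano in place of phenoxy on an aromatic carbon. Among the measured compounds shown here, the only measured step, from isopropylsulfanyl to phenoxy, concerns a different exchange at the same place and was within the scatter, so no measured step bears directly on the replacement of phenoxy by cyano. Both measured substituents at this place gave strong inhibition, and cyano is far smaller than either. Compound 3 is therefore expected to show a step of a 3.0-fold higher number from compound 2 to compound 3 (0.48 log units; beyond the scatter) in this assay, toward a somewhat higher number with wide uncertainty. The estimate for compound 3 is 30 nM, expected to lie between 8 nM and 120 nM.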

Compound 3, half-maximal inhibitory concentration: 70 nM
Estimate against measurement, compound 3: 2.3-fold (0.37 log units) below; the range from low to high includes it.
By their numbers in this assay, from the lowest: compounds 2 and 1 (each within the scatter of the next); then compound 3.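

In this assay, the place ortho to the methylsulfonyl group turns out not to accept every group equally: cyano in place of phenoxy gives a 7.0-fold higher number from compound 2 to compound 3 (0.85 log units; beyond the scatter), and cyano in place of isopropylsulfanyl gives a 5.8-fold higher number from compound 1 to compound 3 (0.77 log units; beyond the scatter). The earlier step, which lay within the scatter, showed no such separation, whereas cyano, with 2 heavy atoms and no ring against the 7 heavy atoms and aromatic ring of phenoxy, stands apart from both earlier groups. No available evidence accounts for this step.

Three compounds cannot separate the loss of the ring, the lower count of heavy atoms and the arrival of the triple bond, as these change together between phenoxy and cyano. On these data alone, how an amine, a carboxylic acid or a longer alkyl chain on this aromatic carbon would stand in this assay also remains open.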